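Carbonyl substituent change in the series

The compounds below may be only part of what the source reports. "The series", "measured", "known", "first", "only" and "open" are said of these compounds alone.

Two compounds have numbers in an in vivo ADME assay on the whole organism (strain CD-1) for pharmacokinetics, with Mus musculus as the target, at a dose of 2.5 mg/kg by the intravenous route; on this read-out higher numbers stand for fast clearance and lower numbers for slow clearance. Compound 1 (`COc1cc(N2CCC(CC(=O)N3CCOCC3)CC2)ccc1Nc1nc(NC2CCCCC2)c2nc[nH]c2n1`) gives 23.3 mL/min/kg and compound 2 (`COc1cc(N2CCC(CC(=O)N3CCN(C)CC3)CC2)ccc1Nc1nc(NC2CCCCC2)c2nc[nH]c2n1`) gives 20.9 mL/min/kg on this read-out. Compound 2 therefore stands level with compound 1, the two values lying within the scatter of repeated measurements. Compound 3 (`COc1cc(N2CCC(CC(=O)N3CCCC3)CC2)ccc1Nc1nc(NC2CCCCC2)c2nc[nH]c2n1`) carries pyrrolidin-1-yl in place of 4-methylpiperazin-1-yl on a carbonyl carbon. Going by the values given here, only one measured step bears on this change, the exchange of morpholin-4-yl for 4-methylpiperazin-1-yl on a carbonyl carbon (a 1.1-fold lower number from compound 1 to compound 2 (0.05 log units; within the scatter)). That step stays within the scatter, so two different six-membered non-aromatic rings at this place have so far given no separable values. Neither measured compound carries a five-membered non-aromatic ring, which leaves the evidence for compound 3 thin. No step beyond the scatter is expected in this assay and no direction can be assigned, the expected step being a 1.1-fold higher number from compound 2 to compound 3 (0.04 log units; within the scatter) in size. Compound 3 is expected at 23 mL/min/kg with an estimated range from 12 mL/min/kg to 42 mL/min/kg for its clearance.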

Compound 3, clearance: 34.2 mL/min/kg
Compound 3: middle estimate off by 1.5-fold (0.17 log units), on the low side, and the stated range covers the measured number.
By their numbers in this assay, from the lowest: compounds 2, 1 and 3 (each within the scatter of the next).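

In this assay the pyrrolidin-1-yl amide brings a five-membered non-aromatic ring to this place on the carbonyl carbon, and the two new comparisons read a 1.6-fold higher number from compound 2 to compound 3 (0.21 log units; within the scatter) against 4-methylpiperazin-1-yl and a 1.5-fold higher number from compound 1 to compound 3 (0.17 log units; within the scatter) against morpholin-4-yl. Together with the earlier pair, this means that all three rings at this place, whether six-membered or five-membered and whether they hold one hetero atom or two, remain inseparable on this read-out, so within these three compounds the position shows no step beyond the scatter. Nothing measured alongside these clearance numbers bears on what lies behind them.

Still open, going by these compounds, is whether a group of another kind on the carbonyl carbon, such as an open-chain dimethylamino group, or a carboxylic acid in place of the amide, would give a step beyond the scatter in this assay and so mark out a real limit for this position. Also open is whether a longer chain leading to the carbonyl carbon, or a smaller azetidin-1-yl ring on it, would separate from the three rings shown here.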